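From 4-butylphenyl to phenethyl

The compounds below may be only part of what the source reports. "The series", "measured", "known", "first", "only" and "open" are said of these compounds alone.

In a functional assay on HepG2 cells (Homo sapiens) for antiproliferative activity, read by MTT assay, with a stated time of 3 days (on this read-out lower numbers stand for stronger inhibition and higher numbers for weaker inhibition), compound 1 `CCCCCc1ccc(C#Cc2cn(C/C=C/CN3C(=O)c4ccccc4C3=O)c(=O)[nH]c2=O)cc1` gives 4300 nM, and compound 2 `CCCCc1ccc(C#Cc2cn(C/C=C/CN3C(=O)c4ccccc4C3=O)c(=O)[nH]c2=O)cc1` gives 9100 nM, the higher of the two numbers. Compound 3 `O=C1c2ccccc2C(=O)N1C/C=C/Cn1cc(C#CCCc2ccccc2)c(=O)[nH]c1=O` carries phenethyl in place of 4-butylphenyl on a triple-bonded carbon. Going by the values given here, only one measured step bears on this change: a 2.1-fold higher number from compound 1 to compound 2 (0.33 log units; beyond the scatter). That modest step, beyond the scatter, put hydrogen in place of methyl on a saturated chain carbon, and the number rose. Among the compounds with values here, no measured step replaces a group on the triple-bonded carbon, so this guide is loose. Going by that single step, a further modest-to-moderate rise is expected in this assay, with weaker inhibition. The expected change is a 1.6-fold higher number from compound 2 to compound 3 (0.22 log units; within the scatter). Compound 3 is estimated at 15000 nM, with an expected range of 6000 nM to 40000 nM.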

Compound 3, half-maximal inhibitory concentration: 7300 nM
Estimate against measurement, compound 3: 2.1-fold (0.31 log units) above; the range from low to high includes it.
By their numbers in this assay, from the lowest: compounds 1, 3 and 2 (each within the scatter of the next, the first and the last beyond it).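

In this assay the change on the triple-bonded carbon reads as follows: a 1.2-fold lower number from compound 2 to compound 3 (0.10 log units; within the scatter), and a 1.7-fold higher number from compound 1 to compound 3 (0.23 log units; within the scatter), with both steps within the scatter. Phenethyl, with fewer heavy atoms than 4-butylphenyl, therefore cannot be told apart from 4-butylphenyl or 4-pentylphenyl at this position, even though compound 1 and compound 2 themselves differ by a step beyond the scatter. No measurement at hand offers an explanation for this result.

Going by these compounds, it remains open whether a plain pentyl chain, a longer phenylpropyl group or a terminal amine on the triple-bonded carbon would give a number in the same range. On these data alone, it is also open whether the match between compound 3 and the other two compounds would hold on cell lines other than HepG2.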